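Swapping the amide allyl for cyclopropyl in compound 1

The source may report more compounds than this note shows. Statements on the series, on what has been measured and on what is new or still open speak of the compounds shown alone.

Compound 1 `C=CCNC(=O)/C(C)=C(\C)c1ccc(OC)cc1` was tested in a toxicity assay on the whole organism (strain Icem-CET (SPF Caw)) for cytotoxicity, with Mus musculus as the target (on this read-out higher numbers stand for an effect only at larger amounts of compound and lower numbers for an effect already at smaller amounts), where compound 1 gives 300 mg/kg, the highest of the two numbers seen. Going by the values given here, its only measured neighbour, compound 2 `C=CCNC(=O)/C(C)=C(\C)c1ccc(C)cc1`, gives 170 mg/kg; the step of a 1.8-fold lower number from compound 1 to compound 2 (0.25 log units; within the scatter) alters the aromatic carbon, not the amide-type nitrogen. Compound 3 `COc1ccc(/C(C)=C(\C)C(=O)NC2CC2)cc1` differs from compound 1 by cyclopropyl in place of allyl on an amide-type nitrogen. Among the compounds with values here, no measured step touches this amide-type nitrogen, so nothing known argues for a shift beyond the scatter, and the step of no change at the digits printed from compound 1 to compound 3 (within the scatter) is therefore expected to be small. Compound 3 is estimated at 300 mg/kg, within 150 mg/kg to 600 mg/kg.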

Compound 3, dose for half-maximal effect: 300 mg/kg
Estimate against measurement, compound 3: no gap at the digits printed; the measured number falls inside the stated range.
By their numbers in this assay, from the lowest: compounds 2, 1 and 3 (each within the scatter of the next).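

In this assay, going by these compounds alone, this is the first reading at the amide-type nitrogen, and swapping allyl for cyclopropyl gives no change at the digits printed from compound 1 to compound 3 (within the scatter). On the core of compound 1, the open chain with its double bond and the three-membered ring of carbon only therefore read alike. No measurement here explains this match.

As far as these compounds go, whether a longer chain, a benzyl group or a chain carrying an amine on this nitrogen would move the number remains open. So does whether the same swap reads alike with the methyl of compound 2 on the aromatic carbon.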